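Longer Chain on Compound 2: Expected Cytotoxicity

The source may report more compounds than this note shows. Statements on the series, on what has been measured and on what is new or still open speak of the compounds shown alone.

Measured in a functional assay on SiHa cells (Homo sapiens) for cytotoxicity, read by MTT assay, with a stated time of 48 h; a lower number here means a stronger inhibitor, a higher number a weaker inhibitor:
compound 1 `CCCCCCCCCCCCCCCCCCNC(=O)[C@@H](N)[C@@H](C)O` gives 39500 nM
compound 2 `CCCCCCCCCCCCCCNC(=O)[C@@H](NC(=O)c1ccco1)[C@@H](C)O` gives 127000 nM

Compound 2 stands at the highest of the two numbers, and compound 1 stands lower; the two differ in more than one place, so only their values can be set side by side. Compound 3 `CCCCCCCCCCCCCCCCCCNC(=O)[C@@H](NC(=O)c1ccco1)[C@@H](C)O` is compound 2 with butyl in place of hydrogen on a saturated chain carbon, ten or more bonds along the chain from an amide-type nitrogen. Within the data shown here, no measured pair isolates this change. Compound 1 carries the longer chain and gives 39500 nM, which hints at a move to a lower number, though compound 1 also differs elsewhere. Compound 3 is expected to give about 80000 nM, between 30000 nM and 200000 nM. The step of a 1.6-fold lower number from compound 2 to compound 3 (0.20 log units; within the scatter) is expected to be modest, possibly not beyond the scatter.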

Compound 3, half-maximal inhibitory concentration: 13400 nM
Beside the measured number, compound 3's estimate is 6.0-fold (0.78 log units) above it; measured number outside the range, below it.
By their numbers in this assay, from the lowest: compound 3; then compound 1; then compound 2.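

In this assay, butyl in place of hydrogen on a saturated chain carbon, ten or more bonds along the chain from an amide-type nitrogen, gives a 9.5-fold lower number from compound 2 to compound 3 (0.98 log units; beyond the scatter), so this position clearly responds to added chain length. With the longer chain in place, (furan-2-yl)carbonyl in place of hydrogen on the amine nitrogen gives a 2.9-fold lower number from compound 1 to compound 3 (0.47 log units; beyond the scatter). No available evidence explains either step. From the compounds shown here alone, whether a still longer chain would lower the number further remains open, as does whether benzoyl on that nitrogen would do the same as (furan-2-yl)carbonyl.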